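Chloro for nitro on the fused ring of the sulfonamide core

This account rests on a few compounds, and the source may have more. Where it says the series, first, only, none or still open, it means among the compounds named here.

Measured compounds:
compound 1, `Cc1ccc2c(c1)CCN2S(=O)(=O)c1ccc(-c2cnc(C3CC3)o2)cc1`, 63.4%
compound 2, `CS(=O)(=O)c1ccc2c(c1)CCN2S(=O)(=O)c1ccc(-c2cnc(C3CC3)o2)cc1`, 4.14%
compound 3, `O=[N+]([O-])c1ccc2c(c1)N(S(=O)(=O)c1ccc(-c3cnc(C4CC4)o3)cc1)CC2`, 50.3%

In a functional assay on A549 cells (Homo sapiens) for inhibition, read by MTT assay, tested at 10 uM (a higher number here means more inhibition at the concentration tested (going by the name of the read-out), a lower number less inhibition), compound 3 stands second of the three, with compound 1 giving a higher number and compound 2 a far lower one. Compound 4, `O=S(=O)(c1ccc(-c2cnc(C3CC3)o2)cc1)N1CCc2ccc(Cl)cc21`, differs from compound 3 in one place: chloro in place of nitro on an aromatic carbon. Going by the values given here, the only measured step at that place is a number 59.3 percentage points lower from compound 1 to compound 2 (beyond the scatter), where a methylsulfonyl entered for a methyl; nothing measured involves a chloro. Compound 1 and compound 3 together suggest that a small group without acceptors there sits near or somewhat above compound 3, so a modest upward step a number 4.7 percentage points higher from compound 3 to compound 4 (within the scatter) is expected. Compound 4 is therefore estimated at 55%, within 35% to 72%.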

Compound 4, a percentage reported as inhibition, at one concentration (the size of the read-out at that concentration, not a potency): 63.6%
Compound 4: the middle estimate sits 8.6 percentage points below what was measured; low and high end bracket the measured number.
By their numbers in this assay, from the lowest: compound 2; then compound 3; then compounds 1 and 4 (each within the scatter of the next).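

Going by these compounds alone, with chloro in place of nitro, this assay shows a number 13.3 percentage points higher from compound 3 to compound 4 (beyond the scatter), so the methyl of compound 1 is no longer the only group at this position to give a number near the top of the set. Compound 4 at 63.6% and compound 1 at 63.4% lie within the scatter of each other. No evidence on hand bears on this step.

As far as these compounds go, an amine or a methoxy group at this place remains open, including whether either would stay with chloro and methyl or fall towards compound 2. The compounds also leave open how these single-concentration numbers relate to potency.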